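Cyano in Place of Fluoro: Compound 2 to Compound 3

The source may hold more compounds than are shown below. What is called first, only, known or untested is meant among the compounds shown, and "the series" means these compounds.

Within the data shown here, compound 2 `Cc1nc2cc(OC[C@H](O)CN3CCN(Cc4noc(-c5cccc(F)c5)n4)CC3)ccc2s1` is one of two compounds measured in a functional assay on mitochondria from heart for inhibition of peroxisomal acyl-coenzyme A oxidase 1 (Rattus norvegicus); on this read-out higher numbers stand for weaker inhibition and lower numbers for stronger inhibition. In this assay, among the measured compounds shown here, compound 2 gives 13400 nM, the highest of the two numbers; its only neighbour, compound 1 `Cc1nc2cc(OC[C@H](O)CN3CCN(Cc4noc(-c5ccc(C(C)C)cc5)n4)CC3)ccc2s1`, gives 950 nM in this assay. For the measured compounds named here, the single measured step, a 14-fold higher number from compound 1 to compound 2 (1.15 log units; beyond the scatter), accompanies the exchange of 4-isopropylphenyl for 3-fluorophenyl on an aromatic carbon.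

Compound 3 `Cc1nc2cc(OC[C@H](O)CN3CCN(Cc4noc(-c5cccc(C#N)c5)n4)CC3)ccc2s1` differs from compound 2 by cyano in place of fluoro on an aromatic carbon of a six-membered aromatic ring of carbon only, meta to a large group. Going by the values given here, no measured step touches this particular exchange; the one step available changes both the substituent and where it sits, so it shows only that a change on this ring can move this assay by a large margin. Among the compounds with values here, with no direct precedent, compound 3 is expected to stay near compound 2, the expected step being a 1.1-fold lower number from compound 2 to compound 3 (0.05 log units; within the scatter), in neither direction beyond the scatter. The estimate for compound 3 in this assay is therefore 12000 nM, within 4000 nM to 40000 nM.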

Compound 3, half-maximal inhibitory concentration: 13400 nM
Compound 3: the middle estimate sits 1.1-fold (0.05 log units) below what was measured, and the stated range covers the measured number.
By their numbers in this assay, from the lowest: compound 1; then compounds 2 and 3 (each within the scatter of the next).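

In this assay, the exchange of fluoro for cyano on this aromatic carbon gives no change at the digits printed from compound 2 to compound 3 (within the scatter) and so separates the 3-fluorophenyl and 3-cyanophenyl compounds not at all, even though the entering cyano carries a triple bond and a hydrogen-bond acceptor that fluoro lacks. The large gap to the 4-isopropylphenyl compound now appears with a second group as well, as a 14-fold higher number from compound 1 to compound 3 (1.15 log units; beyond the scatter) shows, so among these three compounds it no longer rests on the 3-fluorophenyl compound alone. No measurement at hand accounts for the match between the two groups or for the gap to compound 1.

Going by these compounds, whether that gap belongs to the isopropyl group itself or to where it sits stays open, as each step to compound 1 changes both the substituent and its place on the ring. How an amine, a carboxylic acid or a longer alkyl chain would read on this ring is also left unsettled by the compounds shown, and so is whether any such group would move the number away from the level shared by compound 2 and compound 3.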